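Amide aryl exchange at the carbonyl carbon; tolerance on THP-1

The source may hold more compounds than are shown below. What is called first, only, known or untested is meant among the compounds shown, and "the series" means these compounds.

Compound 1 `COc1ccc(C(=O)Nc2ncc(-c3ccc(OC)cc3)n2C)cc1` and compound 2 `COc1ccc(-c2cnc(NC(=O)c3ccccc3C)n2C)cc1` share one core and differ only at the carbonyl carbon. In a toxicity assay on THP-1 cells (Homo sapiens) for inhibition (a lower number here means that less compound is tolerated, a higher number that more compound is tolerated), compound 1 gives only a limit, > 100000 nM. In this assay compound 2 likewise gives only a limit, > 100000 nM. Among the compounds with values here, the one measured step, a step that the two limits leave unreadable from compound 1 to compound 2, therefore cannot be read in size, and compound 2 stands at the limit together with compound 1 (the limit of > 100000 nM in this assay, at which 2 of the 2 values shown sit).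

Compound 3 `COc1ccc(-c2cnc(NC(=O)c3ccncc3)n2C)cc1` is not yet measured. Its change from compound 2 is pyridin-4-yl in place of 2-methylphenyl on a carbonyl carbon. Within the data shown here, no measured step bears directly on this exchange; the only step, a step that the two limits leave unreadable from compound 1 to compound 2, concerns a different aryl group on the same carbonyl carbon and is itself unreadable. Since both measured compounds sit at the limit (the limit of > 100000 nM in this assay, at which 2 of the 2 values shown sit), no step beyond the scatter in this assay is expected in either direction. Compound 3 is therefore expected to give 100000 nM, between 50000 nM and 200000 nM. The step this estimate means, a number no higher from compound 2 to compound 3 (the limit leaves the size open), is expected to stay within the scatter, and the result is most likely to appear again as a limit.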

Compound 3, half-maximal cytotoxic concentration: > 100000 nM
Compound 3: a limit, no number; the forecaster's own chance of this, stated with the estimate: 80%; the middle value sits exactly at the limit.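

Compound 3 gives only a limit in this assay, > 100000 nM. No step among compound 1, compound 2 and compound 3 can be read in size, as all three stand at the limit: the limit of > 100000 nM in this assay, at which 3 of the 3 values shown sit.

Left open is whether 4-methoxyphenyl, 2-methylphenyl and pyridin-4-yl on the carbonyl carbon differ at all in tolerated concentration.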